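Cyclohexyl for Methyl on the Amino Nitrogen: Cytotoxicity Outlook

A few compounds are considered here, and "the series" means these few. Any claim that something is new, unique, unknown or untested is made for them only; others in the source may bear on it.

Among the measured compounds shown here, compound 1 `CNc1nc(N)nc2c1ncn2/C=C1/CC1(CO)CO` is the only compound here with an actual number in an ADME assay on HFF cells (Homo sapiens) for cytotoxicity, with a stated time of 8 days; on this read-out higher numbers stand for lower toxicity in this test and lower numbers for higher toxicity in this test; in it compound 1 gives 265000 nM. Compound 2 `CN(C)c1nc(N)nc2c1ncn2/C=C1/CC1(CO)CO` reaches only a limit of the assay in this assay, > 300000 nM. Compound 3 `Nc1nc(NCc2ccccc2)c2ncn(/C=C3/CC3(CO)CO)c2n1` likewise gives just a limit, > 300000 nM. Compound 4 `Nc1nc(NC2CCCCC2)c2ncn(/C=C3/CC3(CO)CO)c2n1` has not been measured; it differs from compound 1 by cyclohexyl in place of methyl on a nitrogen on an aromatic ring. For the measured compounds named here, two measured steps bear on this change: an at least 1.1-fold higher number from compound 1 to compound 2 (0.05 log units; that floor lies within the scatter) and an at least 1.1-fold higher number from compound 1 to compound 3 (0.05 log units; that floor lies within the scatter), both stopping at the limit of > 300000 nM in this assay, at which 2 of the 3 values shown sit, so their full size stays unknown. With compound 2 and compound 3 both sitting at the limit of > 300000 nM in this assay, at which 2 of the 3 values shown sit, compound 4 is expected to show a 1.1-fold higher number from compound 1 to compound 4 (0.04 log units; within the scatter). Compound 4 is therefore estimated at 290000 nM, within 130000 nM to 650000 nM.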

Compound 4, half-maximal cytotoxic concentration: > 300000 nM
Compound 4 ended at the assay's limit (the forecaster's own chance of this, stated with the estimate: 55%); middle value at least 1.0-fold (0.01 log units) away from the limit.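

Putting cyclohexyl in place of methyl on this nitrogen gives an at least 1.1-fold higher number from compound 1 to compound 4 (0.05 log units; that floor lies within the scatter) in this assay. So a six-membered non-aromatic ring of carbon only, like the benzyl of compound 3, brings no sign of greater toxicity in this test, although compound 4 gives only a limit and not a number. The steps among compound 2, compound 3 and compound 4 cannot be read because all three stop at the same point: the limit of > 300000 nM in this assay, at which 3 of the 4 values shown sit.

How far any of these compounds lies beyond that limit stays open. So does whether a cyclohexyl carrying an amine or a carboxylic acid, or a longer chain on this nitrogen, would lower the number.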